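Methyl on the Ring Nitrogen of a Kinase Inhibitor Core

This account rests on a few compounds, and the source may have more. Where it says the series, first, only, none or still open, it means among the compounds named here.

Measured so far:
compound 1 `CC1(C)NC(=O)c2sc(-c3ccncc3)cc2N1`: 90 nM
compound 2 `CC1(CC(F)(F)F)NC(=O)c2sc(-c3ccncc3)cc2N1`: 31 nM

In an assay for inhibition of Rho-associated protein kinase 1 (Homo sapiens), read by TR-FRET, with stated times of 5 min and 2 h (on this read-out lower numbers stand for stronger inhibition and higher numbers for weaker inhibition), compound 1 gives 90 nM, the highest of the two numbers, with compound 2 nearest; the step of a 2.9-fold lower number from compound 1 to compound 2 (0.46 log units; beyond the scatter) places the trifluoromethyl on a saturated chain carbon. Compound 3 `CN1c2cc(-c3ccncc3)sc2C(=O)NC1(C)C` differs from compound 1 by methyl in place of hydrogen on a nitrogen on an aromatic ring in a ring. Going by the values given here, no measured step touches that nitrogen, so the only comparison is indirect and does not bear on it. The change in this assay is therefore expected to stay within the scatter, in no clear direction, and compound 3 is estimated at 110 nM (range 35 nM to 350 nM), a step of a 1.2-fold higher number from compound 1 to compound 3 (0.09 log units; within the scatter).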

Compound 3, half-maximal inhibitory concentration: 140 nM
Compound 3: middle estimate off by 1.3-fold (0.10 log units), on the low side; low and high end bracket the measured number.
By their numbers in this assay, from the lowest: compound 2; then compounds 1 and 3 (each within the scatter of the next).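

In this assay, going by these compounds alone, the first measured change at this ring nitrogen, methyl in place of hydrogen, gives a 1.6-fold higher number from compound 1 to compound 3 (0.19 log units; within the scatter). The nitrogen can therefore carry one methyl instead of its hydrogen without a change that can be told apart from the scatter. No available evidence gives a reason for this result.

On these data alone, whether a longer chain such as ethyl, or a larger group such as benzyl, would be accepted on this nitrogen stays open. So does whether methyl here would read the same on compound 2.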